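Replacing 4-(dimethylamino)phenyl with 3-chlorophenyl

A few compounds are considered here, and "the series" means these few. Any claim that something is new, unique, unknown or untested is made for them only; others in the source may bear on it.

Compound 1 `CC1=CC[C@@H]([C@@](C)(O)CCCC(C)(C)NC=S)CC1` gives a limit (> 100000 nM)
Compound 2 `CC1=CC[C@@H]([C@@](C)(O)CCCC(C)(C)NC(=S)N/N=C\c2ccccc2)CC1` gives a number (60400 nM)
Compound 3 `CC1=CC[C@@H]([C@@](C)(O)CCCC(C)(C)NC(=S)N/N=C\c2ccc(N(C)C)cc2)CC1` gives a limit (> 100000 nM)

All three were tested in a functional assay on MCF7 cells (Homo sapiens) for cytotoxicity, read by sulforhodamine B assay (a higher number here means that more compound is tolerated, a lower number that less compound is tolerated), and compound 3 has no number, only a limit (the limit of > 100000 nM in this assay, at which 2 of the 3 values shown sit).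

Compound 4 `CC1=CC[C@@H]([C@@](C)(O)CCCC(C)(C)NC(=S)N/N=C\c2cccc(Cl)c2)CC1` carries 3-chlorophenyl in place of 4-(dimethylamino)phenyl on a carbon with a double bond to nitrogen.

Among the measured compounds shown here, two measured steps bear on this change. Placing dimethylamino in place of hydrogen on an aromatic carbon gave an at least 1.6-fold higher number from compound 2 to compound 3 (0.21 log units; that floor lies within the scatter) and the earlier step gave an at least 1.6-fold lower number from compound 1 to compound 2 (0.21 log units; that floor lies within the scatter). Both are only minimum sizes, so they guide weakly. Compound 4 lacks dimethylamino, as does compound 2 (60400 nM), so a number near that value is expected. A limit remains possible for compound 4.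

The expected change is a modest one towards a lower number (an at least 2.0-fold lower number from compound 3 to compound 4 (0.30 log units; that floor lies within the scatter)).

For compound 4 the estimated value is 50000 nM, with an expected range from 18000 nM to 100000 nM.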

Compound 4, concentration lethal to 50% of the cells: 45900 nM
For compound 4 the middle estimate is 1.1-fold (0.04 log units) above the measured one; the measured number falls inside the stated range.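

In this assay, among the compounds shown here, 3-chlorophenyl in place of 4-(dimethylamino)phenyl on this carbon gives an at least 2.1-fold lower number from compound 3 to compound 4 (0.33 log units; beyond the scatter), the first step in this short series printed as beyond the scatter. Chloro in place of hydrogen on an aromatic carbon gives a 1.3-fold lower number from compound 2 to compound 4 (0.12 log units; within the scatter), so this assay does not separate compound 2 from compound 4. The first of these steps is only a minimum size, since compound 3 has a limit and no number: the limit of > 100000 nM in this assay, at which 2 of the 4 values shown sit.

From the compounds shown here alone, the true size of the step from compound 3 therefore remains unknown. Also open, going by these compounds, is whether a different group on the aromatic ring, such as a methoxy group, a primary amine or a carboxylic acid, would shift the number beyond the scatter relative to compound 2.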